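Fluoro on the methyl analogue: expected cytotoxicity step

The compounds below may be only part of what the source reports. "The series", "measured", "known", "first", "only" and "open" are said of these compounds alone.

Values in a functional assay on A549 cells (Homo sapiens) for cytotoxicity, read by MTT assay, with a stated time of 72 h; on this read-out lower numbers stand for stronger inhibition and higher numbers for weaker inhibition
- compound 1 `CNC(=O)c1cc(Oc2ccc(NC(=O)c3nccc(-c4ccccc4)n3)cc2)ccn1` gives 26200 nM
- compound 2 `CNC(=O)c1cc(Oc2ccc(NC(=O)c3nccc(-c4ccc(OC)cc4)n3)cc2F)ccn1` gives 16600 nM
- compound 3 `CNC(=O)c1cc(Oc2ccc(NC(=O)c3nccc(-c4ccc(C)cc4)n3)cc2)ccn1` gives 28400 nM

Compound 3 stands at 28400 nM in this assay, within the scatter of the values of compound 1 and compound 2, so the three compounds form one group with no order among them.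

The compound now in question is compound 4 `CNC(=O)c1cc(Oc2ccc(NC(=O)c3nccc(-c4ccc(C)cc4)n3)cc2F)ccn1`. It carries fluoro in place of hydrogen on an aromatic carbon, ortho to a (2-(methylcarbamoyl)pyridin-4-yl)oxy group and meta to a large group: fluoro in place of hydrogen on an aromatic carbon.

Among the measured compounds shown here, no measured pair isolates this change. For the measured compounds named here, the one measured step, a 1.1-fold higher number from compound 1 to compound 3 (0.04 log units; within the scatter), concerns the methyl group rather than the fluoro and stays within the scatter, so it bears on the change only indirectly. The closest evidence is a compound that also carries the fluoro but has methoxy in place of the methyl: compound 2, which gives 16600 nM, within the scatter of the value of compound 3.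

No step beyond the scatter is therefore expected in this assay, and any drift is expected towards the value of compound 2. The estimated step is a 1.4-fold lower number from compound 3 to compound 4 (0.13 log units; within the scatter), which stays within the scatter. The estimate for compound 4 is 21000 nM, with an expected range from 11000 nM to 40000 nM.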

Compound 4, half-maximal inhibitory concentration: 33200 nM
Estimate against measurement, compound 4: 1.6-fold (0.20 log units) below; measured number inside the range.
By their numbers in this assay, from the lowest: compounds 2, 1, 3 and 4 (each within the scatter of the next).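

In this assay, fluoro in place of hydrogen on an aromatic carbon, ortho to a (2-(methylcarbamoyl)pyridin-4-yl)oxy group, gives a 1.2-fold higher number from compound 3 to compound 4 (0.07 log units; within the scatter); this is the only pair shown that isolates the change, and on the methyl analogue it produces no step beyond the scatter. With the fluoro held constant, methyl in place of methoxy gives a 2.0-fold higher number from compound 2 to compound 4 (0.30 log units; within the scatter), so the two fluoro compounds do not separate either, and the four values form a single group with no order among them. No supporting data bear on the origin of these steps.

The compounds shown leave open whether chloro or an amine at this same position, in place of the fluoro, would produce a step beyond the scatter in this cytotoxicity read-out. Also open, from the compounds shown here alone, is whether a carboxylic acid in place of the methyl of compound 3 would move the value, and whether the fluoro gives a similar step on the core of compound 1.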